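Dropping the methyl from an aryl thiosemicarbazone

A few compounds are considered here, and "the series" means these few. Any claim that something is new, unique, unknown or untested is made for them only; others in the source may bear on it.

Of the compounds shown here, three have so far been tested in a functional assay on HT-29 cells (Homo sapiens) for antiproliferative activity, read by sulforhodamine B assay, with a stated time of 72 h; on this read-out lower numbers stand for stronger inhibition and higher numbers for weaker inhibition. Compound 1 `COc1ccc(C)cc1NC(=S)N/N=C/c1ccc2ccccc2n1` stops at the limit of > 100000 nM in this assay. Compound 2 `Cc1cccc(NC(=S)N/N=C/c2ccc3ccccc3n2)c1` likewise reaches only the limit of > 100000 nM. Compound 3 `NC(=S)N/N=C/c1cnc2ccccc2n1`, which carries no aryl group on the thiourea nitrogen, also gives only the limit of > 100000 nM. All three values sit at the limit of > 100000 nM in this assay, at which 3 of the 3 values shown sit, so compound 2 stands at that limit exactly as compound 1 and compound 3 do, with no number to set it apart from either. Among the measured compounds shown here, the single step between measured compounds, a step that the two limits leave unreadable from compound 1 to compound 2, is unreadable, both of its ends being limits.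

Compound 4 `S=C(N/N=C/c1ccc2ccccc2n1)Nc1ccccc1` differs from compound 2 by hydrogen in place of methyl on an aromatic carbon. The step that the two limits leave unreadable from compound 1 to compound 2 is the only measured one that touches the same aryl ring, and its size cannot be read, so there is no measured change of known size to build on. With every value at the limit and the change itself small, no step beyond the scatter is expected in this assay. Compound 4 is therefore expected to give 200000 nM, with a range from 50000 nM to 1000000 nM. The expected step is a step that the limit leaves unreadable from compound 2 to compound 4.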

Compound 4, half-maximal inhibitory concentration: 17000 nM
Compound 4: middle estimate off by 12-fold (1.07 log units), on the high side; the measured number lies below the stated range.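

In this assay, replacing the methyl with hydrogen, which turns 3-methylphenyl into phenyl, gives an at least 5.8-fold lower number from compound 2 to compound 4 (0.76 log units; beyond the scatter). Among the compounds shown here, this is the first change with a readable effect, and it shows that this aromatic carbon, meta to a large group, is a place where removing one methyl separates two compounds beyond the scatter. The size of the step is only a minimum, as the value of compound 2, > 100000 nM, is a limit of the assay. Compound 4, with 17000 nM, is the only one of the four to give a number and not a limit: the limit of > 100000 nM in this assay, at which 3 of the 4 values shown sit.

The compounds shown leave open whether a chlorine, a hydroxyl or an amine at this same place would hold the number of compound 4 or return to the limit. On these data alone, the step from compound 1 to compound 2 cannot be read, its two ends being limits, so it also remains open how groups elsewhere on the phenyl ring of compound 4, such as a methoxy, would act alone.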